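The source may hold more compounds than are shown below. What is called first, only, known or untested is meant among the compounds shown, and "the series" means these compounds.

Compound 3 `CC(/C=N/Nc1ccc([N+](=O)[O-])cc1)=N\NC(=O)c1ccccc1Cl` has not yet been tested, but two close relatives have. In an ADME assay on J774 cells (Mus musculus, strain BALB/c) for cytotoxicity, read by resazurin assay, with a stated time of 72 h (a lower number here means that less compound is tolerated, a higher number that more compound is tolerated), compound 1 `CC(/C=N/Nc1ccc([N+](=O)[O-])cc1)=N\NC(=O)c1ccc(Cl)cc1` gives 63900 nM. Compound 2 `CC(/C=N/Nc1ccc([N+](=O)[O-])cc1)=N\NC(=O)c1ccccc1Oc1ccccc1` sits at the limit of > 100000 nM in this assay, at which 1 of the 2 values shown sits, so for it only a limit of > 100000 nM is known rather than a number. Going from compound 2 to compound 3, the change is chloro in place of phenoxy on an aromatic carbon. Among the compounds with values here, no measured pair shows this same change, so the step cannot be read off. In this assay the expected step is a modest downward one of about an at least 1.4-fold lower number from compound 2 to compound 3 (0.15 log units; that floor lies within the scatter). Compound 3 is estimated at 70000 nM, with a range from 30000 nM to 150000 nM.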

Compound 3, half-maximal cytotoxic concentration: > 100000 nM
Compound 3 gave a limit, no number; the forecaster's own chance of this, stated with the estimate: 35%; middle value at least 1.4-fold (0.15 log units) from the limit.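

Compared with compound 1, placing the chlorine as 2-chlorophenyl rather than 4-chlorophenyl on the carbonyl carbon gives, in this assay, an at least 1.5-fold higher number from compound 1 to compound 3 (0.19 log units; that floor lies within the scatter). Replacing phenoxy with the much smaller chloro still leaves a limit and no number, so a large group at this place is not needed to reach that limit. Compound 2 and compound 3 are both limits, so the step between them cannot be read: the limit of > 100000 nM in this assay, at which 2 of the 3 values shown sit.

As far as these compounds go, whether an amine or a carboxylic acid on this aromatic carbon would give a measurable number remains open. So does the true value of compound 2 and of compound 3.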